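A few compounds are considered here, and "the series" means these few. Any claim that something is new, unique, unknown or untested is made for them only; others in the source may bear on it.

Compound 1, `O=C(CSc1nc(Nc2ccccc2)c2ccccc2n1)Nc1cccc(Br)c1`, gives 10100 nM in a functional assay on NCI-H1975 cells (Homo sapiens) for inhibition, read by MTT assay, with a stated time of 72 h; on this read-out lower numbers stand for stronger inhibition and higher numbers for weaker inhibition.
Compound 2, `COc1cccc(NC(=O)CSc2nc(Nc3ccccc3)c3ccccc3n2)c1`, gives 19400 nM.
Compound 3, `O=C(CSc1nc(Nc2ccccc2)c2ccccc2n1)Nc1ccc(C(F)(F)F)cc1`, gives 11700 nM.

Compound 3 stands second highest of the three numbers; its nearest neighbour is compound 1, with a 1.2-fold higher number from compound 1 to compound 3 (0.06 log units; within the scatter), and its furthest is compound 2, with a 1.7-fold lower number from compound 2 to compound 3 (0.22 log units; within the scatter). All three differ only in the group on the amide-type nitrogen, and every such step stayed within the scatter. Compound 4, `CCc1ccc(NC(=O)CSc2nc(Nc3ccccc3)c3ccccc3n2)cc1`, is not yet measured; it differs from compound 3 by ethyl in place of trifluoromethyl on an aromatic carbon. Since the two measured changes at this ring, from compound 1 and from compound 2, moved the number by less than the scatter, no step beyond the scatter is expected in this assay. Compound 4 is therefore estimated at 11000 nM, in the range 5000 nM to 25000 nM, meaning an expected step of a 1.1-fold lower number from compound 3 to compound 4 (0.03 log units; within the scatter).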

Compound 4, half-maximal inhibitory concentration: 9910 nM
The estimate for compound 4 lay 1.1-fold (0.05 log units) above the measured number, within the range that was stated.
By their numbers in this assay, from the lowest: compounds 4, 1, 3 and 2 (each within the scatter of the next).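

In this assay, ethyl in place of trifluoromethyl on this aromatic carbon gives a 1.2-fold lower number from compound 3 to compound 4 (0.07 log units; within the scatter), so swapping a fluorine-bearing group for an all-carbon one moves the number no further than the scatter. The other two comparisons, a 2.0-fold lower number from compound 2 to compound 4 (0.29 log units; within the scatter) and a 1.0-fold lower number from compound 1 to compound 4 (0.01 log units; within the scatter), also stay within the scatter, so all four groups on the amide-type nitrogen read alike so far. Nothing measured here explains this sameness. On these data alone, whether an amine, a carboxylic acid or a longer chain on this ring would move the number beyond the scatter stays open. So does the effect of any change to the shared core.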